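Carboxylic acid analogues at the assay limit

The source may report more compounds than this note shows. Statements on the series, on what has been measured and on what is new or still open speak of the compounds shown alone.

Measured so far:
compound 1, `CCOC(=O)c1cnc(NCc2ccc(F)cc2)n2nc(-c3ccco3)nc12`: 1970 nM
compound 2, `CNc1ncc(C(=O)O)c2nc(-c3ccco3)nn12`: > 10000 nM
compound 3, `Cc1ccc(CNc2ncc(C(=O)O)c3nc(-c4ccco4)nn23)cc1`: > 10000 nM

In a functional assay on CHO cells for antagonist activity at adenosine receptor A2b (Homo sapiens) (a lower number here means a stronger inhibitor, a higher number a weaker inhibitor), compound 1 gives 1970 nM. For compound 2 the reported value > 10000 nM is a limit of the assay, not a number. For compound 3 the value > 10000 nM is likewise a limit. Among the compounds with values here, the one step joining two measured compounds, a step that the two limits leave unreadable from compound 2 to compound 3, has no readable size due to the limit of > 10000 nM in this assay, at which 2 of the 3 values shown sit. Compound 3 therefore stands only at that limit, with no number of its own.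

Compound 4, `O=C(O)c1cnc(NCc2ccc(F)cc2)n2nc(-c3ccco3)nc12`, differs from compound 3 by fluoro in place of methyl on an aromatic carbon. Within the data shown here, no measured step covers this change, so it gives no direction. Compound 1 carries the same 4-fluorobenzyl group with an ethyl ester in place of the acid and gives 1970 nM. Compound 2 and compound 3, the two acids measured, both sit at the limit. Compound 4 is therefore expected also to sit at or near the limit, estimated at 15000 nM with a range from 4000 nM to 50000 nM. The expected step that the limit leaves unreadable from compound 3 to compound 4 is thus estimated as none beyond the scatter.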

Compound 4, inhibition constant: > 30000 nM
Compound 4 was reported as a limit; the forecaster's own chance of this, stated with the estimate: 70%; at least 2.0-fold (0.30 log units) between middle value and limit.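

In this assay, within the data shown here, with the 4-fluorobenzyl group held constant, going from the ethyl ester to the carboxylic acid gives an at least 15-fold higher number from compound 1 to compound 4 (1.18 log units; beyond the scatter), the first readable comparison of these two groups. For compound 4, the reported > 30000 nM is a limit of the assay, not a number. The steps linking compound 2, compound 3 and compound 4 cannot be read, so fluoro in place of methyl on the aromatic carbon has no measurable size here, and all three acids shown remain at limits.

The compounds shown leave open whether a primary amide or a hydroxymethyl group in place of the ester would give a readable value. They also leave open whether a 4-methylbenzyl group on the ethyl ester would read apart from the 4-fluorobenzyl group of compound 1.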